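Aryl replacement at the benzyl ether in a secretagogue-receptor series

A few compounds are considered here, and "the series" means these few. Any claim that something is new, unique, unknown or untested is made for them only; others in the source may bear on it.

Measured compounds:
compound 1 `CC(C)(N)C(=O)N[C@H](COCc1ccccc1C#N)c1nnnn1CCOC(=O)NCCCCO` — 1.26 nM
compound 2 `CC(C)(N)C(=O)N[C@H](COCc1ccccc1-c1ccccc1)c1nnnn1CCOC(=O)NCCCCO` — 0.34 nM

In a functional assay on cells for inhibition of growth hormone secretagogue receptor type 1 (Homo sapiens), read by FLIPR and calcium flux (a higher number here means that more compound is needed for the effect, a lower number that less compound is needed), compound 1 gives 1.26 nM and compound 2 gives 0.34 nM; compound 2 holds the lowest of the two numbers. Within the data shown here, the only measured step, a 3.7-fold lower number from compound 1 to compound 2 (0.57 log units; beyond the scatter), is the sole guide. Compound 3 `Cc1noc(C)c1-c1ccccc1COC[C@@H](NC(=O)C(C)(C)N)c1nnnn1CCOC(=O)NCCCCO` differs from compound 2 by 3,5-dimethyl-1,2-oxazol-4-yl in place of phenyl on an aromatic carbon. Among the measured compounds shown here, no measured step covers this exchange; both groups are aromatic rings, and the one step shows the number falling when an aromatic ring replaced a nitrile, so only a small change is expected, the estimated step of a 1.8-fold higher number from compound 2 to compound 3 (0.25 log units; within the scatter) lying within or close to the scatter. Compound 3 is expected at 0.6 nM, ranging from 0.15 nM to 2.5 nM.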

Compound 3, half-maximal effective concentration: 1.04 nM
Compound 3: the middle estimate sits 1.7-fold (0.24 log units) below what was measured; the measured number falls inside the stated range.
By their numbers in this assay, from the lowest: compound 2; then compounds 3 and 1 (each within the scatter of the next).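

In this assay the aromatic carbon bearing these groups separates one aromatic ring from another (a 3.1-fold higher number from compound 2 to compound 3 (0.49 log units; beyond the scatter)), so the gain seen with phenyl does not extend to 3,5-dimethyl-1,2-oxazol-4-yl. Against the nitrile (a 1.2-fold lower number from compound 1 to compound 3 (0.08 log units; within the scatter)), compound 3 cannot be told apart from compound 1, so an aromatic ring here does not by itself lower the number. Nothing on hand accounts for the gap between the two rings.

On these data alone, whether a pyridine ring, or a phenyl ring carrying an amine or a carboxylic acid, would match compound 2 remains open.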